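From Compound 3 to the Methylsulfonyl Compound 4

This account rests on a few compounds, and the source may have more. Where it says the series, first, only, none or still open, it means among the compounds named here.

In a functional assay on the whole organism for antagonist activity, with Mus musculus as the target (on this read-out higher numbers stand for an effect only at larger amounts of compound and lower numbers for an effect already at smaller amounts), compound 1 `CC[S+]([O-])c1nnc(-c2ccccc2)n1C` gives 14.4 mg/kg as a measured number. Compound 2 `CSc1nnc(-c2cccc3ccccc23)n1C` reaches only > 200 mg/kg and this is a limit of the assay. Compound 3 `Cn1c(-c2cccc3ccccc23)nnc1[S+](C)[O-]` likewise reaches only > 200 mg/kg and this too is a limit. Compound 3 therefore has no number of its own and stands with compound 2 at the limit of > 200 mg/kg in this assay, at which 2 of the 3 values shown sit.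

Compound 4 `Cn1c(-c2cccc3ccccc23)nnc1S(C)(=O)=O` differs from compound 3 in one place: a group of 4 heavy atoms (1 carbon, 2 oxygen, 1 sulfur; no ring) in place of a group of 3 heavy atoms (1 carbon, 1 oxygen, 1 sulfur; no ring), on an aromatic carbon. The new methylsulfonyl group sits on an aromatic carbon of a five-membered aromatic ring with 3 nitrogen, between two ring nitrogen atoms.

For the measured compounds named here, only one measured step bears on this place, and it is a step that the two limits leave unreadable from compound 2 to compound 3. It offers no size to carry over and no direction either. Going by the values given here, compound 1 has a number, but no step connects it to compound 4. The expectation therefore rests on compound 3 remaining at the limit of > 200 mg/kg in this assay, at which 2 of the 3 values shown sit, and on the unreadable step that the two limits leave unreadable from compound 2 to compound 3, and it foresees no clear gain. The expected change is a step that the limit leaves unreadable from compound 3 to compound 4 and this remains only an estimate. Compound 4 is estimated at 250 mg/kg with an expected range from 100 mg/kg to 500 mg/kg and a report of only a limit is the likeliest outcome.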

Compound 4, dose for half-maximal effect: > 200 mg/kg
Compound 4: no number, only a limit (the forecaster's own chance of this, stated with the estimate: 70%); the middle value lies beyond the limit too.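

In this assay, compound 4 gives only a limit, as do compound 2 and compound 3, so none of the steps among these three compounds can be read: the limit of > 200 mg/kg in this assay, at which 3 of the 4 values shown sit. The compounds shown leave open whether methylsulfanyl, the group of compound 3 and methylsulfonyl differ at all on this shared core, since each result remains a limit.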